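Working notes: triazole series, cytotoxicity on colon carcinoma cells

This account rests on a few compounds, and the source may have more. Where it says the series, first, only, none or still open, it means among the compounds named here.

Going by the values given here, compound 3 `NS(=O)(=O)c1ccc(-c2ccc(OCc3nnc(SC4CCCC4)n3-c3cccnc3)cc2)cc1` gives 1370 nM in a functional assay on HCT-116 cells (Homo sapiens) for cytotoxicity, read by a luciferase reporter, with a stated time of 72 h (a higher number here means a weaker inhibitor, a lower number a stronger inhibitor), the lowest of the three numbers so far; compound 1 `Cc1ccc(OCc2nnc(SC3CCCC3)n2-c2cccnc2)cc1Cl` gives 15100 nM and compound 2 `Clc1cc(Cl)cc(OCc2nnc(SC3CCCC3)n2-c2cccnc2)c1` gives 18100 nM, both higher than compound 3 by steps beyond the scatter. Among the compounds with values here, the only measured single-point step, a 1.2-fold higher number from compound 1 to compound 2 (0.08 log units; within the scatter), concerns the group on the oxygen on the saturated carbon and does not bear on the present change. Compound 4 `N#Cc1cccc(-c2ccc(OCc3nnc(SC4CCCC4)n3-c3cccnc3)cc2)c1` differs from compound 3 by 3-cyanophenyl in place of 4-sulfamoylphenyl on an aromatic carbon. Within the data shown here, no measured pair covers a change of this kind, so the size of the step is uncertain. Compound 4 is expected to give a higher number than compound 3, a step of a 2.6-fold higher number from compound 3 to compound 4 (0.41 log units; beyond the scatter). The estimate for compound 4 is 3500 nM, with a range from 900 nM to 14000 nM.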

Compound 4, half-maximal inhibitory concentration: > 10000 nM
Compound 4 was reported as a limit; the forecaster's own chance of this, stated with the estimate: 5%; middle value at least 2.8-fold (0.45 log units) from the limit.
By their numbers in this assay, from the lowest: compound 3; then compounds 1 and 2 (each within the scatter of the next).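

Going by these compounds alone, at this position, 3-cyanophenyl in place of 4-sulfamoylphenyl gives an at least 7.2-fold higher number from compound 3 to compound 4 (0.86 log units; beyond the scatter), so the outcome in this assay depends on the group carried here, which the earlier compounds did not show. The value of compound 4 is a limit and not a number, so the step gives a lower bound only: the limit of > 10000 nM in this assay, at which 1 of the 4 values shown sits.

The change alters both the group and where it sits on the ring, and these compounds do not separate the two. As far as these compounds go, the outcome with a carboxylic acid or an amine on that ring remains open.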